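Three meta-substituted analogues at the cytotoxicity limit

The compounds below may be only part of what the source reports. "The series", "measured", "known", "first", "only" and "open" are said of these compounds alone.

Measured compounds:
- compound 1, `CCOC(=O)c1c(-c2cccc(Oc3ccccc3)c2)[nH]c2cc(OC)ccc2c1=O`: > 21500 nM in an ADME assay on BJ cells (Homo sapiens) for cytotoxicity, read by luminescence, with a stated time of 72 h; a lower number here means that less compound is needed, a higher number that more compound is needed for the effect; this is a limit of the assay, not a number.
- compound 2, `CCOC(=O)c1c(-c2cccc(F)c2)[nH]c2cc(OC)ccc2c1=O`: > 21500 nM; again a limit, not a number.
- compound 3, `CCOC(=O)c1c(-c2cccc(C(C)=O)c2)[nH]c2cc(OC)ccc2c1=O`: > 21500 nM; again a limit, not a number.

All three measured compounds share one core and differ only in the group on the aromatic carbon that carries the phenoxy in compound 1. Compound 1 stands at the limit of the assay, and no number places it apart from the others. The steps a step that the two limits leave unreadable from compound 1 to compound 2, a step that the two limits leave unreadable from compound 1 to compound 3 and a step that the two limits leave unreadable from compound 2 to compound 3 are each unreadable in size and direction, because of the limit of > 21500 nM in this assay, at which 3 of the 3 values shown sit.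

Compound 4, `CCOC(=O)c1c(-c2cccc(CO)c2)[nH]c2cc(OC)ccc2c1=O`, is the next member of the set. Its change from compound 1 is hydroxymethyl in place of phenoxy on an aromatic carbon.

Among the measured compounds shown here, no measured step bears readably on this change, since every value in the set is a limit. The expectation for compound 4 is therefore that it too will sit at the limit of the assay, with the step that the limit leaves unreadable from compound 1 to compound 4 expected to be unreadable in the same way. Compound 4 is estimated at 30000 nM, with a range from 15000 nM to 80000 nM, and most likely reported only as a limit.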

Compound 4, half-maximal effective concentration: > 21500 nM
Compound 4: only a limit was reported; the forecaster's own chance of this, stated with the estimate: 85%; the middle value does not contradict the limit.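

No new step can be read in this assay between compound 4 and compound 1, compound 2 or compound 3, because each value is a limit and not a number: the limit of > 21500 nM in this assay, at which 4 of the 4 values shown sit.

The compounds shown leave open whether the four differ at all in this assay, and in which direction any difference would run.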